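The source may hold more compounds than are shown below. What is called first, only, known or untested is meant among the compounds shown, and "the series" means these compounds.

In an in vivo ADME assay on the whole organism (strain 129/SvEvBrd x C57BL/6) for pharmacokinetics, with Mus musculus as the target (on this read-out lower numbers stand for lower oral bioavailability and higher numbers for higher oral bioavailability), compound 1 `CC(=O)c1ncc([C@@H](O)[C@H](O)[C@H](O)CO)s1` gives 65% on a core of its own. Compound 2 `CC(=O)N/N=C(\C)c1nc([C@@H](O)[C@H](O)[C@H](O)CO)c[nH]1` gives 5% and compound 3 `CN(C)C(=O)c1nc([C@@H](O)[C@H](O)[C@H](O)CO)c[nH]1` gives 5% on a shared core, so compound 3 stands level with compound 2, together the lowest of the three numbers and beyond the scatter from compound 1. Compound 4 `OC[C@@H](O)[C@@H](O)[C@H](O)c1c[nH]c(-c2ncc[nH]2)n1` keeps that shared core, with 1H-imidazol-2-yl in place of dimethylcarbamoyl on an aromatic carbon as the change from compound 3. Among the measured compounds shown here, no measured pair differs in one place. Compound 2 at 5% and compound 3 at 5% carry different groups at this place yet sit level, so in this assay no step beyond the scatter is expected, with any drift more likely upward. The estimated change is a number 7 percentage points higher from compound 3 to compound 4 (within the scatter) on this scale. For compound 4 the expected value is 12% within a range of 3% to 35% in this assay for now.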

Compound 4, oral bioavailability: 28%
The estimate for compound 4 lay 16 percentage points below the measured number; measured number inside the range.
By their numbers in this assay, from the lowest: compounds 2 and 3 (each within the scatter of the next); then compound 4; then compound 1.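

In this assay the place on an aromatic carbon between two ring nitrogen atoms responds to the group it carries: 1H-imidazol-2-yl in place of dimethylcarbamoyl gives a number 23 percentage points higher from compound 3 to compound 4 (beyond the scatter), whereas compound 2 and compound 3 sat level with different groups there. Among the compounds shown here, this is the first step read on the shared core, and it rests on a single pair. Nothing available accounts for this step. Going by these compounds, whether a pyridyl ring, an amine or a carboxylic acid at this place would move the number further stays open.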